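Methyl in place of methoxy: notes on compound 3

The source may hold more compounds than are shown below. What is called first, only, known or untested is meant among the compounds shown, and "the series" means these compounds.

Of the compounds shown here, two have been measured so far in an ADME assay for permeability, using PAMPA, at pH 7.4; on this read-out higher numbers stand for higher permeability and lower numbers for lower permeability. Compound 1 `Cc1[nH]c2ccccc2c(=O)c1Br` gives 13.6 10^-6 cm/s, and compound 2 `COc1ccc2[nH]c(C)c(Br)c(=O)c2c1` gives 16.7 10^-6 cm/s. These two values lie within the scatter of each other, so no order can be read between them, and compound 2 stands with compound 1 on the numbers at hand.

The next compound is compound 3 `Cc1ccc2[nH]c(C)c(Br)c(=O)c2c1`, which has methyl in place of methoxy on an aromatic carbon of compound 2. The counted difference is as follows: methyl in place of methoxy on an aromatic carbon.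

Going by the values given here, one measured step bears on this change: methoxy in place of hydrogen on an aromatic carbon, which gives a 1.2-fold higher number from compound 1 to compound 2 (0.09 log units; within the scatter). Among the compounds with values here, no measured step exchanges methoxy for methyl directly, so this evidence is indirect. On that single small step, no change beyond the scatter is expected in this assay, and no direction is favoured.

The expected change is a 1.0-fold higher number from compound 2 to compound 3 (0.01 log units; within the scatter). The estimate for compound 3 is 17 10^-6 cm/s, with an expected range from 8 10^-6 cm/s to 33 10^-6 cm/s.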

Compound 3, apparent permeability: 42.2 10^-6 cm/s
For compound 3 the middle estimate is 2.5-fold (0.39 log units) below the measured one; the whole stated range lies below it.
By their numbers in this assay, from the lowest: compounds 1 and 2 (each within the scatter of the next); then compound 3.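

In this assay this aromatic carbon, described as meta to a fused ring and para to a fused ring, proves sensitive to the group it carries: methyl in place of methoxy gives a 2.5-fold higher number from compound 2 to compound 3 (0.40 log units; beyond the scatter) and methyl in place of hydrogen gives a 3.1-fold higher number from compound 1 to compound 3 (0.49 log units; beyond the scatter), both modest but beyond the scatter. Methoxy in place of hydrogen gave only a 1.2-fold higher number from compound 1 to compound 2 (0.09 log units; within the scatter) and stayed within the scatter, so the earlier pair alone gave no sign that the position could move the number, and methyl now stands apart from both hydrogen and methoxy, with compound 3 the highest of the three. Nothing at hand gives a reason for the separation of methyl from the other two groups.

On these data alone, whether this rise belongs to methyl alone remains open, since an ethyl group, a longer chain, a chlorine atom or an amine on the same carbon would show whether the number keeps rising, levels off or falls. Also open, as far as these compounds go, is whether methyl in place of hydrogen gives a step of similar size on the other aromatic carbons of the shared core.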